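Dropping a Nitrogen Between the Carbonyl and the Aryl Ring

A few compounds are considered here, and "the series" means these few. Any claim that something is new, unique, unknown or untested is made for them only; others in the source may bear on it.

Of the compounds shown here, two have been measured in a functional assay on NCI/ADR-RES cells (Homo sapiens) for inhibition, read by sulforhodamine B assay, with a stated time of 48 h, tested at 10 uM; on this read-out lower numbers stand for a stronger effect and higher numbers for a weaker effect at the one concentration tested. Compound 1 `COc1cc(Cl)cc(-c2nn(-c3cccc(NC(=O)Nc4ccc(Cl)c(C(F)(F)F)c4)c3)cc2-c2ccncc2)c1` gives 6.07%, and compound 2 `COc1cc(Cl)cc(-c2nn(-c3cccc(NC(=O)Nc4cccc(C(F)(F)F)c4)c3)cc2-c2ccncc2)c1` gives 3.58%. On these two numbers compound 2 holds the lower of the pair, with compound 1 sitting a number 2.5 percentage points lower from compound 1 to compound 2 (within the scatter), so the two are not distinguishable.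

Compound 3 `COc1cc(Cl)cc(-c2nn(-c3cccc(NC(=O)c4cccc(C(F)(F)F)c4)c3)cc2-c2ccncc2)c1` has not yet been measured in this assay. It differs from compound 2 in a single place: 3-(trifluoromethyl)phenyl in place of (3-(trifluoromethyl)phenyl)amino on a carbonyl carbon. Among the compounds with values here, the one measured step, from compound 1 to compound 2, concerns a different spot on the molecule, swapping hydrogen for chloro on an aromatic carbon, and it moved the read-out only within the scatter. Within the data shown here, no measured pair tests the change made at the carbonyl carbon, so there is no direct guide to its size or direction.

Without such a guide, compound 3 is expected to stay near its parent, the estimated step being a number 6.4 percentage points higher from compound 2 to compound 3 (within the scatter). The estimate for compound 3 in this assay is 10%, within a range of 0% to 40%, a deliberately wide band reflecting how little the measured steps say about this change.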

Compound 3, a percentage reported as activity, at one concentration (the size of the read-out at that concentration, not a potency): 46.7%
The estimate for compound 3 lay 36.7 percentage points below the measured number; the measured number lies above the stated range.
By their numbers in this assay, from the lowest: compounds 2 and 1 (each within the scatter of the next); then compound 3.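

In this assay, replacing the (3-(trifluoromethyl)phenyl)amino group on the carbonyl carbon with 3-(trifluoromethyl)phenyl gives a number 43.1 percentage points higher from compound 2 to compound 3 (beyond the scatter) and so a clearly weaker effect at the one concentration tested. Measured against the chloro-bearing parent, the same kind of replacement gives a number 40.6 percentage points higher from compound 1 to compound 3 (beyond the scatter) and points the same way, so this place on the molecule responds strongly to a change, unlike the chloro position, where the earlier step stayed within the scatter. The group that leaves counts 1 hydrogen-bond donor and the group that enters counts 0, but nothing shown here gives a measured reason for the large step.

Compounds 1, 2 and 3 show this replacement only as a whole and say nothing about the amino nitrogen alone. An oxygen atom or a methylene group at the same place on the carbonyl carbon would help to test this. As far as these compounds go, it also remains open whether the chloro group, which made no difference beyond the scatter in the earlier pair, would matter on the ring of compound 3.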